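The source may report more compounds than this note shows. Statements on the series, on what has been measured and on what is new or still open speak of the compounds shown alone.

Compound 3 `CN(C[C@H]1Cc2c(cccc2N2CCN(c3cccc(C(F)(F)F)c3)CC2)CN1)[C@H]1CCCc2cccnc21` gives 90.3% in an ADME assay on microsomes from liver (Homo sapiens) for metabolic stability, read by LC-MS, with a stated time of 10 min; on this read-out lower numbers stand for a less stable compound and higher numbers for a more stable compound. Its nearest neighbour among the measured compounds is compound 1 `CN(C[C@H]1Cc2c(cccc2N2CCN(C3COC3)CC2)CN1)[C@H]1CCCc2cccnc21` with 83.1%, and the step of a number 7.2 percentage points higher from compound 1 to compound 3 (within the scatter). Far away stands compound 2 `CCN1CCN(c2cccc3c2C[C@H](CN(C)[C@H]2CCCc4cccnc42)NC3)CC1`, which gives 0% in this assay; here a number 90.3 percentage points higher from compound 2 to compound 3 (beyond the scatter), and likewise a number 83.1 percentage points lower from compound 1 to compound 2 (beyond the scatter). Compound 4 `CN(C[C@H]1Cc2c(cccc2N2CCN(c3ccccn3)CC2)CN1)[C@H]1CCCc2cccnc21` differs from compound 3 in one place: pyridin-2-yl in place of 3-(trifluoromethyl)phenyl on an amine nitrogen in a ring. Among the compounds with values here, the steps that bear on this change are the ones that exchanged the group on that ring nitrogen, and both aromatic groups gave numbers close to each other while only the ethyl group fell away. A step of a number 12.3 percentage points lower from compound 3 to compound 4 (beyond the scatter) is therefore expected, within the scatter. Compound 4 is estimated to give 78%, with a range from 55% to 95%.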

Compound 4, percent of the compound remaining: 27.4%
Estimate against measurement, compound 4: 50.6 percentage points above, and the stated range ends above it.
By their numbers in this assay, from the lowest: compound 2; then compound 4; then compounds 1 and 3 (each within the scatter of the next).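

In this assay, an aromatic ring on this amine nitrogen does not by itself go with a high number: pyridin-2-yl and 3-(trifluoromethyl)phenyl part widely (a number 62.9 percentage points lower from compound 3 to compound 4 (beyond the scatter)). Pyridin-2-yl also falls well short of oxetan-3-yl (a number 55.7 percentage points lower from compound 1 to compound 4 (beyond the scatter)), yet it stays clear of ethyl (a number 27.4 percentage points higher from compound 2 to compound 4 (beyond the scatter)). Nothing available explains these differences. From the compounds shown here alone, whether the step follows the ring nitrogen of pyridin-2-yl or the loss of the trifluoromethyl stays open; a plain phenyl on the same nitrogen would separate the two.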